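A few compounds are considered here, and "the series" means these few. Any claim that something is new, unique, unknown or untested is made for them only; others in the source may bear on it.

Measured so far: compound 1 `Oc1cccc(-c2cc(-c3ccccc3F)cc(-c3ccccc3O)n2)c1` gives 31100 nM. Compound 2 `Oc1ccc(-c2cc(-c3ccccc3F)cc(-c3ccccc3O)n2)cc1` gives a limit only, > 50000 nM. Compound 3 `Oc1cccc(-c2cc(-c3ccc(OC(F)(F)F)cc3)cc(-c3cccc(O)c3)n2)c1` gives 18700 nM.

In a functional assay on HeLa cells (Homo sapiens) for inhibition (on this read-out lower numbers stand for stronger inhibition and higher numbers for weaker inhibition), compound 1 gives 31100 nM. For compound 2 this assay reports no number but only a limit, > 50000 nM. Compound 3 gives 18700 nM in this assay, the lowest number of the two that are numbers. Compound 2 differs from compound 1 by 4-hydroxyphenyl in place of 3-hydroxyphenyl on an aromatic carbon; this change gave an at least 1.6-fold higher number from compound 1 to compound 2 (0.20 log units; that floor lies within the scatter), and the floor of that step is set because of the limit of > 50000 nM in this assay, at which 1 of the 3 values shown sits. How the core of compound 3 differs from that of compound 1 is not broken down here.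

Compound 4 `Oc1ccc(-c2cc(-c3ccc(OC(F)(F)F)cc3)cc(-c3cccc(O)c3)n2)cc1` is not yet measured. It differs from compound 3 by 4-hydroxyphenyl in place of 3-hydroxyphenyl on an aromatic carbon. The surroundings are not the same: in compound 1 the place is meta to a 2-fluorophenyl group and meta to a 2-hydroxyphenyl group, in compound 3 it is meta to a 3-hydroxyphenyl group and meta to a large group, so this is the same kind of change rather than the same change. From compound 3 to compound 4 a step of a 2.4-fold higher number from compound 3 to compound 4 (0.38 log units; beyond the scatter) is expected in this assay, resting on the step of an at least 1.6-fold higher number from compound 1 to compound 2 (0.20 log units; that floor lies within the scatter), which is only a floor. Compound 4 is estimated at 45000 nM, between 18000 nM and 120000 nM, with a real chance that this assay again reports only a limit.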

Compound 4, half-maximal inhibitory concentration: 27800 nM
The estimate for compound 4 lay 1.6-fold (0.21 log units) above the measured number, and the stated range covers the measured number.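

In this assay, going by these compounds alone, 4-hydroxyphenyl in place of 3-hydroxyphenyl gives a 1.5-fold higher number from compound 3 to compound 4 (0.17 log units; within the scatter), so on this core the change produces no step that can be told from the scatter. Set beside the earlier case, the result reads: the same change on two cores in this assay, an at least 1.6-fold higher number (0.20 log units; that floor lies within the scatter) from compound 1 to compound 2 and a 1.5-fold higher number (0.17 log units; within the scatter) from compound 3 to compound 4; the limit leaves it open whether they differ. The two cores therefore show no conflict, but they do not show that the change carries over at the same size, since the step on the core of compound 1 is only a floor and its true size could be larger: the limit of > 50000 nM in this assay, at which 1 of the 4 values shown sits.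

The compounds shown offer just two cores and only a hydroxyl on the ring that changes, so they leave open whether the same small step would appear on a third core, for instance one carrying neither 2-fluorophenyl nor the trifluoromethoxy-bearing ring. They also leave open how an amine or a carboxylic acid in place of that hydroxyl would read in this assay.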